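The compounds below may be only part of what the source reports. "The series", "measured", "known", "first", "only" and "open" are said of these compounds alone.

Compound 1, `FC(F)(F)c1ccccc1-c1nc(NCc2ccccc2)c2ccccc2n1`, gives 3100 nM in an assay on a protein complex for inhibition of ubiquitin carboxyl-terminal hydrolase 1/WD repeat-containing protein 48 (Homo sapiens), read by fluorescence; a lower number here means a stronger inhibitor, a higher number a weaker inhibitor. Compound 2, `FC(F)(F)c1ccccc1-c1nc(NCc2ccc(-c3ccc(Cl)c(Cl)c3)cc2)c2ccccc2n1`, gives 2200 nM in this assay, and compound 3, `FC(F)(F)c1ccccc1-c1nc(NCc2ccc(-c3ccncc3)cc2)c2ccccc2n1`, gives 1900 nM. Compound 3 has the lowest of the three numbers, but its gap to compound 2 and its gap to compound 1 both lie within the scatter, so no order among the three can be claimed.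

Compound 4, `FC(F)(F)c1ccccc1-c1nc(NCc2ccc(C3CCCCC3)cc2)c2ccccc2n1`, has not yet been measured. It differs from compound 3 in one place: cyclohexyl in place of pyridin-4-yl on an aromatic carbon. Among the measured compounds shown here, the steps that bear on this change are those that alter the same position. From compound 1 to compound 3 the step was a 1.6-fold lower number from compound 1 to compound 3 (0.21 log units; within the scatter), from compound 1 to compound 2 it was a 1.4-fold lower number from compound 1 to compound 2 (0.15 log units; within the scatter), and from compound 2 to compound 3 it was a 1.2-fold lower number from compound 2 to compound 3 (0.06 log units; within the scatter). None of these moved the number beyond the scatter, whether the group at that position was hydrogen, a 3,4-dichlorophenyl or a pyridin-4-yl. A cyclohexyl at the same place is therefore expected to leave the number close to that of compound 3, with no step beyond the scatter in either direction, which is what a 1.2-fold higher number from compound 3 to compound 4 (0.06 log units; within the scatter) expresses. Compound 4 is estimated at 2200 nM in this assay, within a range from 900 nM to 5500 nM.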

Compound 4, half-maximal inhibitory concentration: 9800 nM
Compound 4: the middle estimate sits 4.5-fold (0.65 log units) below what was measured, and the stated range ends below it.
By their numbers in this assay, from the lowest: compounds 3, 2 and 1 (each within the scatter of the next); then compound 4.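

Until now no group at this position had moved the number beyond the scatter, but cyclohexyl does so against each of the three earlier groups in this assay: in place of pyridin-4-yl (a 5.2-fold higher number from compound 3 to compound 4 (0.71 log units; beyond the scatter)), in place of 3,4-dichlorophenyl (a 4.5-fold higher number from compound 2 to compound 4 (0.65 log units; beyond the scatter)) and in place of hydrogen (a 3.2-fold higher number from compound 1 to compound 4 (0.50 log units; beyond the scatter)). The position therefore does respond to the group it carries, and the response does not follow the count of heavy atoms, since pyridin-4-yl and cyclohexyl have the same count and still differ beyond the scatter. Among the four compounds, the one with a non-aromatic ring at this place stands apart, while the two with an aromatic ring there and the one with hydrogen lie within the scatter of each other, and nothing available gives a reason for this rise in the number.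

As far as these compounds go, it remains open whether the non-aromatic ring as such goes with the higher number, which piperidin-4-yl, with a nitrogen in a non-aromatic ring, or cyclopentyl, with a smaller ring of carbon only, could help to separate. An open chain such as n-hexyl at the same place, or an amine or a carboxylic acid there, would show whether a ring is needed for the change at all.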